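Working notes: from compound 3 to compound 4

The compounds below may be only part of what the source reports. "The series", "measured", "known", "first", "only" and "open" are said of these compounds alone.

Measured compounds:
compound 1 `CCC(C)OC(=O)NS(=O)(=O)c1sc(CC(C)C)cc1-c1cccc(Cn2ccnc2)c1`: 440 nM
compound 2 `CC(C)CCOC(=O)NS(=O)(=O)c1sc(CC(C)C)cc1-c1cccc(Cn2ccnc2)c1`: 230 nM
compound 3 `CC(C)Cc1cc(-c2cccc(Cn3ccnc3)c2)c(S(=O)(=O)NC(=O)OC(C)(C)C)s1`: 270 nM

In an assay on HEK293 cells for displacement of a labelled ligand from Type-2 angiotensin II receptor (Homo sapiens), read by scintillation counting, with a stated time of 240 min (on this read-out lower numbers stand for stronger inhibition and higher numbers for weaker inhibition), compound 3 gives 270 nM, the second highest of the three numbers. Its neighbours sit close: a 1.2-fold higher number from compound 2 to compound 3 (0.07 log units; within the scatter), and a 1.6-fold lower number from compound 1 to compound 3 (0.21 log units; within the scatter). The three measured compounds are alike apart from the group on an oxygen next to a carbonyl group, and the remaining step there, a 1.9-fold lower number from compound 1 to compound 2 (0.28 log units; within the scatter), is also within the scatter; so far, changing that group has moved nothing beyond the scatter.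

Compound 4 `CCCCCC(=O)NS(=O)(=O)c1sc(CC(C)C)cc1-c1cccc(Cn2ccnc2)c1` differs from compound 3 by pentyl in place of tert-butoxy on a carbonyl carbon. Among the measured compounds shown here, none of the measured steps removes the oxygen itself; they only bear on the change indirectly, showing that the group beyond the carbonyl has been tolerant of variation. On that basis the expected step is a 1.1-fold higher number from compound 3 to compound 4 (0.05 log units; within the scatter), with no direction favoured beyond the scatter. For compound 4 the estimated value in this assay is 300 nM, expected between 110 nM and 850 nM.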

Compound 4, inhibition constant: 280 nM
Beside the measured number, compound 4's estimate is 1.1-fold (0.03 log units) above it; the range from low to high includes it.
By their numbers in this assay, from the lowest: compounds 2, 3, 4 and 1 (each within the scatter of the next).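

In this assay the oxygen on the carbonyl carbon is not needed to keep the number at this level: pentyl in place of tert-butoxy is a step within the scatter (a 1.0-fold higher number from compound 3 to compound 4 (0.02 log units; within the scatter)). The same holds against the other two oxygen-linked groups (a 1.2-fold higher number from compound 2 to compound 4 (0.09 log units; within the scatter); a 1.6-fold lower number from compound 1 to compound 4 (0.20 log units; within the scatter)), so the tolerance seen so far extends from the group on that oxygen to the oxygen itself. No measured evidence bears on why this exchange leaves the number within the scatter.

As far as these compounds go, whether an amine, a phenyl ring or a much longer chain on the carbonyl carbon would stay at this level remains open. All four compounds share the same core, so these notes say nothing about changes elsewhere in the structure.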